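Anilinohydrazone variation on a shared core: toward compound 4

The compounds below may be only part of what the source reports. "The series", "measured", "known", "first", "only" and "open" are said of these compounds alone.

Compound 1: `Cn1c(=O)c(=O)n(C2CCCC2)c2nc(N/N=C/c3ccc(S(C)(=O)=O)cc3)ncc21` — 26600 nM
Compound 2: `Cn1c(=O)c(=O)n(C2CCCC2)c2nc(N/N=C/c3ccc(O)c(F)c3)ncc21` — 85200 nM
Compound 3: `Cn1c(=O)c(=O)n(C2CCCC2)c2nc(N/N=C/c3ccc(F)cc3Cl)ncc21` — 15200 nM

Of the compounds shown here, three sharing one core have been tested in a functional assay on PC-3 cells (Homo sapiens) for antiproliferative activity, read by MTT assay; on this read-out lower numbers stand for stronger inhibition and higher numbers for weaker inhibition. Compound 2 gives the highest number of the three; compound 1 sits nearest, and compound 3 furthest, with both steps beyond the scatter: a 3.2-fold higher number from compound 1 to compound 2 (0.51 log units; beyond the scatter) and a 5.6-fold lower number from compound 2 to compound 3 (0.75 log units; beyond the scatter). Compound 4, `Cn1c(=O)c(=O)n(C2CCCC2)c2nc(N/N=C/c3cccc([N+](=O)[O-])c3)ncc21`, has not yet been measured. It arises from compound 2 through one change: 3-nitrophenyl in place of 3-fluoro-4-hydroxyphenyl on a carbon with a double bond to nitrogen.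

Both measured steps that touch this position start from or lead to compound 2, and both show that replacing 3-fluoro-4-hydroxyphenyl at this carbon with another aryl group gave a lower number, modestly so. The 3-nitrophenyl of compound 4, like the 4-(methylsulfonyl)phenyl of compound 1, carries no hydrogen-bond donor and two acceptors, so a similar move is expected. Compound 4 is therefore estimated to give a lower number than compound 2, around 25000 nM (range 10000 nM to 60000 nM), which would correspond to an expected step of a 3.4-fold lower number from compound 2 to compound 4 (0.53 log units; beyond the scatter).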

Compound 4, half-maximal inhibitory concentration: 20300 nM
The estimate for compound 4 lay 1.2-fold (0.09 log units) above the measured number; the range from low to high includes it.
By their numbers in this assay, from the lowest: compounds 3, 4 and 1 (each within the scatter of the next); then compound 2.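

In this assay, the 3-nitrophenyl group places compound 4 with the other non-phenol compounds: a 4.2-fold lower number from compound 2 to compound 4 (0.62 log units; beyond the scatter), whereas a 1.3-fold higher number from compound 3 to compound 4 (0.13 log units; within the scatter) and a 1.3-fold lower number from compound 1 to compound 4 (0.12 log units; within the scatter). Three different aryl groups on this carbon therefore give values that cannot be told apart, while compound 2, the only one of the four with a hydroxyl on its aryl group, remains the weakest. Nothing measured here explains why compound 2 stands apart from the other three.

Going by these compounds, whether the hydroxyl, the fluorine or the two together set compound 2 apart remains open. On these data alone, it is also open whether an unsubstituted phenyl, or an aryl group bearing an amine or a carboxylic acid, would fall with compounds 1, 3 and 4 or with compound 2.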